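The compounds below may be only part of what the source reports. "The series", "measured", "known", "first", "only" and "open" are said of these compounds alone.

Working notes on a small set measured in a physicochemical assay for lipophilicity, read by HPLC, at pH 7.4; a higher number here means a more lipophilic compound, a lower number a more polar compound. Compound 1 `O=C(O)Cc1ccccc1-c1cccc(NC(=O)OCc2ccccc2)c1` gives 3.06 in this assay. Compound 3 `O=C(O)Cc1ccc(-c2ccc(N(C(=O)OCc3ccccc3)C3CCOCC3)cc2)cc1` gives 3.13. Compound 2 `O=C(O)Cc1ccc(-c2ccc(CN3CC(=O)N(C4CCCCC4)C3=O)nc2)cc1` gives -0.35. Among these three numbers compound 1 stands second highest; the value of compound 3 is within the scatter of that of compound 1, so no order can be read between those two, while the value of compound 2 lies far below, beyond the scatter.

The next compound in the series is compound 4 `O=C(Nc1cccc(-c2ccccc2)c1)OCc1ccccc1`, not yet measured in this assay. Against compound 1 the change is hydrogen in place of carboxymethyl on an aromatic carbon. For the measured compounds named here, no measured pair in the set shows this same change, so its size has to be judged from the change itself: a carboxymethyl group leaves and a hydrogen enters, on an aromatic carbon of a six-membered aromatic ring of carbon only, ortho to a large group.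

With compound 1 as the starting point at 3.06, the step from compound 1 to compound 4 is expected to be large and upward, estimated at a number 1.94 log units higher from compound 1 to compound 4 (beyond the scatter). For compound 4 the estimate in this assay is 5, with a likely range from 4.3 to 5.7.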

Compound 4, distribution coefficient: 7.52
Beside the measured number, compound 4's estimate is 2.52 log units below it; the whole stated range lies below it.
By their numbers in this assay, from the lowest: compound 2; then compounds 1 and 3 (each within the scatter of the next); then compound 4.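

In this assay, for the compounds shown here, hydrogen in place of carboxymethyl on an aromatic carbon, ortho to a large group, gives a number 4.46 log units higher from compound 1 to compound 4 (beyond the scatter), and this is the first step that can be read between two compounds differing in one place. The earlier values could only be set side by side across compounds differing in several places, whereas this pair ties a large change in the number to this one carbon and this one group. Compound 4 is also the only compound shown that carries no carboxymethyl group, so all three earlier values come with that group present somewhere in the structure, but nothing measured in this set accounts for the size of the step.

A methyl group, a methyl ester or a primary amide at this same carbon would show whether the step follows the carboxylic acid itself or the whole carboxymethyl group. Whether the same change gives a step of similar size on another core, such as those of compound 2 and compound 3, remains an open question for the series.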